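Swapping the Sulfonyl Aryl Group of a Kallikrein-7 Inhibitor

The compounds below may be only part of what the source reports. "The series", "measured", "known", "first", "only" and "open" are said of these compounds alone.

Of the compounds shown here, two have been measured in an assay on isolated protein for inhibition of kallikrein-7 (Homo sapiens), read by fluorescence, with stated times of 10 min and 30 min; on this read-out lower numbers stand for stronger inhibition and higher numbers for weaker inhibition. Compound 1, `CCC1=NC(c2cn(S(=O)(=O)c3ccc(C)cc3)c3ccccc23)CN1`, gives 24000 nM in this assay. Compound 2, `CC1=NC(c2cn(S(=O)(=O)c3cccs3)c3ccc(C)cc23)CN1`, gives 11000 nM in this assay, the lowest of the two numbers; the gap between compound 2 and compound 1 is larger than the usual scatter, so compound 2 stands as the stronger inhibitor of the pair.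

Compound 3, `CC1=NC(c2cn(S(=O)(=O)c3ccccc3C)c3ccc(C)cc23)CN1`, has not yet been measured. It differs from compound 2 in one place: 2-methylphenyl in place of thiophen-2-yl on a sulfonyl sulfur. Among the compounds with values here, no measured pair shows this particular change, so its effect has to be guessed. Since the two known compounds differ in several places at once, the step of a 1.1-fold higher number from compound 2 to compound 3 (0.04 log units; within the scatter) is expected to be small, most likely within the scatter, in either direction. On that basis compound 3 is expected to give about 12000 nM in this assay, with a range from 5000 nM to 30000 nM.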

Compound 3, half-maximal inhibitory concentration: 1000 nM
Compound 3: middle estimate off by 12-fold (1.08 log units), on the high side; the whole stated range lies above it.
By their numbers in this assay, from the lowest: compound 3; then compound 2; then compound 1.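

The earlier pair differed in several places at once, so it could not show what the group on the sulfonyl sulfur contributes on its own. Here only that group changes: in this assay, 2-methylphenyl in place of thiophen-2-yl gives an 11-fold lower number from compound 2 to compound 3 (1.04 log units; beyond the scatter), a large step beyond the scatter, so this one place can strongly shift inhibition while the rest of the molecule stays the same. Nothing available explains why this change has so large an effect.

The compounds shown leave open whether the gain comes from the six-membered ring alone or needs its methyl group, which a plain phenyl ring would help to separate. They also leave open how a ring carrying methoxy, chlorine or an amine in place of that methyl would behave.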